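Chain extension toward the isothiocyanate end: compound 4

The compounds below may be only part of what the source reports. "The series", "measured", "known", "first", "only" and "open" are said of these compounds alone.

Measured so far in a functional assay on A549 cells (Homo sapiens) for inhibition, read by CCK-8 assay, with a stated time of 72 h, tested at 10 uM; a higher number here means a stronger effect of the compound at the concentration tested, a lower number a weaker effect:
compound 1 `CN(C)C(=O)c1cc2cnc(Nc3ccc(C(=O)NCCCCCN=C=S)cc3)nc2n1C1CCCC1`: 100%
compound 2 `CN(C)C(=O)c1cc2cnc(Nc3ccc(C(=O)NCCCCCN=C=S)cc3F)nc2n1C1CCCC1`: 15.6%
compound 3 `CN(C)C(=O)c1cc2cnc(Nc3ccc(C(=O)NCCCCN=C=S)cc3O)nc2n1C1CCCC1`: 41.7%

Compound 3 stands second highest of the three numbers in this assay: compound 1 gives 100% and compound 2 gives 15.6%, and compound 3 lies beyond the scatter from both. Compound 4 `CN(C)C(=O)c1cc2cnc(Nc3ccc(C(=O)NCCCCCN=C=S)cc3O)nc2n1C1CCCC1` differs from compound 3 by a group of 4 heavy atoms (2 carbon, 1 nitrogen, 1 sulfur; no ring) in place of a group of 3 heavy atoms (1 carbon, 1 nitrogen, 1 sulfur; no ring), on a saturated chain carbon, four bonds along the chain from an amide-type nitrogen. For the measured compounds named here, the only measured step, a number 84.4 percentage points lower from compound 1 to compound 2 (beyond the scatter), concerns a change on the aromatic ring and does not bear on this one; no step for the chain itself has been measured. Compound 1 shares the longer chain with compound 4 but also differs from compound 3 on the aromatic ring, so it gives no clean guide. The expected change is a modest one, a number 8.3 percentage points higher from compound 3 to compound 4 (within the scatter), not confidently beyond the scatter. Compound 4 is estimated at 50%, within 25% to 85%.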

Compound 4, a percentage reported as inhibition, at one concentration (the size of the read-out at that concentration, not a potency): 30.7%
The estimate for compound 4 lay 19.3 percentage points above the measured number; the measured number falls inside the stated range.
By their numbers in this assay, from the lowest: compound 2; then compound 4; then compound 3; then compound 1.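

Extending the chain at the saturated chain carbon gives, in this assay, a number 11 percentage points lower from compound 3 to compound 4 (beyond the scatter), so with hydroxy on the aromatic carbon the added chain atom does not raise the effect. With the group of 4 heavy atoms held constant, hydroxy falls short of hydrogen, at a number 69.3 percentage points lower from compound 1 to compound 4 (beyond the scatter), yet exceeds fluoro, at a number 15.1 percentage points higher from compound 2 to compound 4 (beyond the scatter). No measurement here gives a reason for these steps.

Open, as far as these compounds go, is whether a still longer chain continues the same downward step with hydroxy in place. Also open, from the compounds shown here alone, is where methoxy or an amine on the aromatic carbon would fall relative to hydrogen, hydroxy and fluoro.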